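Replacing the Sulfur-Bearing Group at the Benzylic Carbon

A few compounds are considered here, and "the series" means these few. Any claim that something is new, unique, unknown or untested is made for them only; others in the source may bear on it.

Among the compounds with values here, in a functional assay on RAW264.7 cells (Mus musculus) for inhibition (on this read-out lower numbers stand for stronger inhibition and higher numbers for weaker inhibition), compound 2 `CC(C)(C)OC(=O)N(Cc1ccco1)C(=O)c1ccc(Cn2c(=O)c3ccccc3[s+]2[O-])cc1` gives 68000 nM, the highest of the two numbers measured so far. Compound 1 `CC(C)(C)OC(=O)N(Cc1ccco1)C(=O)c1ccc(CN2Cc3ccccc3C2=O)cc1` gives 51800 nM in this assay. The step of a 1.3-fold higher number from compound 1 to compound 2 (0.12 log units; within the scatter) is small. Compound 3 `CC(C)(C)OC(=O)N(Cc1ccco1)C(=O)c1ccc(Cn2oc3ccccc3c2=O)cc1` differs from compound 2 by a group of 10 heavy atoms (7 carbon, 1 nitrogen, 2 oxygen; one five-membered aromatic ring with 2 hetero atoms, one six-membered aromatic ring of carbon only) in place of a group of 11 heavy atoms (7 carbon, 1 nitrogen, 2 oxygen, 1 sulfur; one five-membered aromatic ring with 2 hetero atoms, one six-membered aromatic ring of carbon only), on a saturated chain carbon bound to an aromatic carbon. Within the data shown here, the only measured step concerns a different exchange at the same place and stayed within the scatter, so nothing here points to a sizeable shift in either direction. A step within the scatter is therefore expected, a 1.1-fold lower number from compound 2 to compound 3 (0.05 log units; within the scatter). Compound 3 is estimated at 60000 nM, with a range from 25000 nM to 150000 nM.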

Compound 3, half-maximal inhibitory concentration: 6690 nM
Compound 3: the middle estimate sits 9.0-fold (0.95 log units) above what was measured; the measured number lies below the stated range.
By their numbers in this assay, from the lowest: compound 3; then compounds 1 and 2 (each within the scatter of the next).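

The saturated chain carbon bound to an aromatic carbon turns out to be able to move this number: the sulfur-free group of 10 heavy atoms gives a 10-fold lower number from compound 2 to compound 3 (1.01 log units; beyond the scatter), and set against the non-aromatic ring group it gives a 7.7-fold lower number from compound 1 to compound 3 (0.89 log units; beyond the scatter). Both steps lie beyond the scatter, so compound 3 is the strongest inhibitor of the three. No measurement shown explains this gain. Still open, on these data alone, is whether a simpler group at this place, such as an amine or a carboxylic acid, would keep it. As far as these compounds go, whether the second ring oxygen is needed also stays open.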